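The compounds below may be only part of what the source reports. "The series", "measured", "known", "first", "only" and "open" are said of these compounds alone.

Among the compounds with values here, compound 2 `CCCCCCCCCCCCCCCCCCNC(=O)[C@@H](NC(=O)c1ccco1)[C@@H](C)O` gives 13400 nM in a functional assay on SiHa cells (Homo sapiens) for cytotoxicity, read by MTT assay, with a stated time of 48 h (a lower number here means a stronger inhibitor, a higher number a weaker inhibitor), the lowest of the two numbers measured so far. Compound 1 `CCCCCCCCNC(=O)[C@@H](NC(=O)c1nccc2ccccc12)[C@@H](C)O` differs from compound 2 in two places; in this assay compound 1 gives 66000 nM, a higher number by a gap beyond the usual scatter. Compound 3 `CCCCCCCCCCCCCCCCCCNC(=O)[C@@H](NC(=O)c1nccc2ccccc12)[C@@H](C)O` keeps the octadecyl chain of compound 2 and carries isoquinolin-1-yl in place of furan-2-yl on a carbonyl carbon. Within the data shown here, no measured pair isolates this change, so its effect is unknown. The step from compound 2 to compound 3 is expected to be small, a 1.3-fold lower number from compound 2 to compound 3 (0.13 log units; within the scatter), not clearly beyond the scatter in either direction. Compound 3 is therefore estimated at 10000 nM, within 3000 nM to 40000 nM.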

Compound 3, half-maximal inhibitory concentration: 51200 nM
For compound 3 the middle estimate is 5.1-fold (0.71 log units) below the measured one; the whole stated range lies below it.
By their numbers in this assay, from the lowest: compound 2; then compounds 3 and 1 (each within the scatter of the next).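

In this assay, isoquinolin-1-yl in place of furan-2-yl on a carbonyl carbon gives a 3.8-fold higher number from compound 2 to compound 3 (0.58 log units; beyond the scatter) and so weakens inhibition, the first measured effect of changing this group. With isoquinolin-1-yl kept, decyl in place of hydrogen on the chain gives a 1.3-fold lower number from compound 1 to compound 3 (0.11 log units; within the scatter) and so shows no clear effect of chain length. No measured evidence explains either result. On these data alone, whether furan-2-yl keeps its advantage on the shorter chain of compound 1 remains open, as does how thiophen-2-yl or phenyl would compare on the same carbonyl.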